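A Larger Sulfur Substituent Tested for Liver-Cell Toxicity

A few compounds are considered here, and "the series" means these few. Any claim that something is new, unique, unknown or untested is made for them only; others in the source may bear on it.

Two compounds built on one shared core, each carrying a side chain on a sulfur, have been tested in a functional assay on HepG2 cells (Homo sapiens) for cytotoxicity, read by MTT assay, with a stated time of 48 h; a lower number here means a stronger inhibitor, a higher number a weaker inhibitor. Compound 1 `C=CCSc1nnc(CC)n1N1C(=O)c2ccccc2C1=O` carries an allyl group on that sulfur and an ethyl group on the core. In this assay compound 1 gives > 200000 nM, which is a limit of the assay rather than a number. Compound 2 `C#CCSc1nnc(-c2cc(OC)c(OC)c(OC)c2)n1N1C(=O)c2ccccc2C1=O` carries a propargyl group on the sulfur and a different substituent on the core. In this assay compound 2 gives > 200000 nM, again a limit and not a number. Compound 2 therefore stands at the limit of > 200000 nM in this assay, at which 2 of the 2 values shown sit, with no numbered value to mark how far it lies from a measurable effect.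

Compound 3 `COc1cc(-c2nnc(SCC(=O)c3ccc(Br)cc3)n2N2C(=O)c3ccccc3C2=O)cc(OC)c1OC` differs from compound 2 in one place: (4-bromophenyl)carbonyl in place of ethynyl on a saturated chain carbon bound to a sulfur. For the measured compounds named here, no measured pair shows this change, so its effect in this assay is unknown. Because compound 2 sits at the limit of > 200000 nM in this assay, at which 2 of the 2 values shown sit, any reported number for compound 3 would have to be a move toward a stronger inhibitor; the expected step is an at least 1.3-fold lower number from compound 2 to compound 3 (0.12 log units; that floor lies within the scatter). Compound 3 is estimated at 150000 nM, between 30000 nM and 400000 nM, with a real chance that only a limit is reported again.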

Compound 3, half-maximal inhibitory concentration: 27700 nM
Compound 3: middle estimate off by 5.4-fold (0.73 log units), on the high side; the measured number lies below the stated range.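

Replacing the ethynyl end of the propargyl group with (4-bromophenyl)carbonyl gives the only actual number among the compounds shown in this assay, with a step of an at least 7.2-fold lower number from compound 2 to compound 3 (0.85 log units; beyond the scatter). This shows that a change on a saturated chain carbon bound to a sulfur can bring the read-out down from the limit to a measurable level, by more than the usual scatter, which two limits alone could not show. As far as these compounds go, the true size of the step remains unknown, and it can only be stated as a minimum because one end of it is a limit rather than a number: the limit of > 200000 nM in this assay, at which 2 of the 3 values shown sit.

The entering group brings a carbonyl, an aromatic ring and a bromine together, and the compounds shown do not tell which of these parts, alone or in combination, accounts for the step. Also open, from the compounds shown here alone, is how the same place would read in this assay with a plain phenylcarbonyl group, a chlorine in place of the bromine, or an amine or a carboxylic acid at the end of the chain.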